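The compounds below may be only part of what the source reports. "The series", "measured", "known", "first", "only" and "open" are said of these compounds alone.

In a functional assay on MCF7 cells (Homo sapiens) for inhibition, read by MTT assay, with a stated time of 48 h (on this read-out higher numbers stand for weaker inhibition and lower numbers for stronger inhibition), compound 1 (`CCOC(=O)C1=C(N/N=C(\C#N)C(N)=O)Nc2[nH]nc(C)c2C1c1ccc(N(C)C)cc1`) gives 50100 nM and compound 2 (`CCOC(=O)C1=C(N/N=C(/C(=O)Br)c2ccc(Br)cc2)Nc2[nH]nc(C)c2C1c1ccc(N(C)C)cc1`) gives 61300 nM and compound 3 (`CCOC(=O)C1=C(N/N=C(/Cl)c2ccc([N+](=O)[O-])cc2)Nc2[nH]nc(C)c2C1c1ccc(N(C)C)cc1`) gives 52700 nM as the data stand so far. Compound 3 lies within the scatter of both other compounds, so the three values form one level with no ranking among them.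

The next compound is compound 4 (`CCOC(=O)C(=NNC1=C(C(=O)OCC)C(c2ccc(N(C)C)cc2)c2c(C)n[nH]c2N1)C(=O)OCC`), and its difference from compound 3 is a group of 12 heavy atoms (7 carbon, 1 nitrogen, 4 oxygen; no ring) in place of a group of 12 heavy atoms (7 carbon, 2 nitrogen, 2 oxygen, 1 chlorine; one six-membered aromatic ring of carbon only), on an amine nitrogen with the shared core unchanged. The group that enters has no ring, while the group that leaves has one six-membered aromatic ring of carbon only.

Among the compounds with values here, three measured steps bear on this change. All of them fall on the same amine nitrogen. They are a 1.2-fold higher number from compound 1 to compound 2 (0.09 log units; within the scatter) and a 1.1-fold higher number from compound 1 to compound 3 (0.02 log units; within the scatter) and a 1.2-fold lower number from compound 2 to compound 3 (0.07 log units; within the scatter) in turn, each within the scatter. Neither exchanging a ringless group for a ring-bearing one nor exchanging one ring-bearing group for another moved the value beyond the scatter. Within the data shown here, no measured compound carries the entering group itself, so the range is kept wide.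

No step beyond the scatter is expected in this assay here. The expected change is a 1.1-fold lower number from compound 3 to compound 4 (0.02 log units; within the scatter) on this estimate. Compound 4 is estimated at 50000 nM with an expected range from 20000 nM to 110000 nM as the likely span.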

Compound 4, half-maximal inhibitory concentration: 89800 nM
Estimate against measurement, compound 4: 1.8-fold (0.25 log units) below; the range from low to high includes it.
By their numbers in this assay, from the lowest: compounds 1, 3, 2 and 4 (each within the scatter of the next).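

In this assay, the amine nitrogen now carries a second ringless group, and removing the aromatic ring still leaves the value within the scatter: a 1.7-fold higher number from compound 3 to compound 4 (0.23 log units; within the scatter) and a 1.5-fold higher number from compound 2 to compound 4 (0.17 log units; within the scatter). Exchanging one ringless group for the other, which differ in their atoms and size, gives a 1.8-fold higher number from compound 1 to compound 4 (0.25 log units; within the scatter), so all four compounds form a single level, and across the groups shown neither the presence of the ring nor the atom make-up of the group separates them. No measurement bears on why these groups give values at one level.

No group shown on this amine nitrogen moves the value beyond the scatter, so the series does not yet show which features of the group, if any, matter in this assay. Within the data shown here, it remains open whether a carboxylic acid, a simple amine or a longer alkyl chain at this place would leave compounds at the same level or produce the first step beyond the scatter.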